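This account rests on a few compounds, and the source may have more. Where it says the series, first, only, none or still open, it means among the compounds named here.

Values in an assay on isolated protein for inhibition of histone deacetylase 8 (Homo sapiens) (on this read-out higher numbers stand for weaker inhibition and lower numbers for stronger inhibition), for the measured members of the series:

compound 1 `O=C(CCCCCCCC(=O)c1ccccc1)NO` — 65 nM
compound 2 `COc1ccc(C(=O)CCCCCCCC(=O)NO)cc1` — 15 nM
compound 3 `O=C(CCCCCCCC(=O)c1ccc(-c2ccc(Br)cc2)cc1)NO` — 2 nM

Compound 3 holds the lowest number of the three, with a 7.5-fold lower number from compound 2 to compound 3 (0.88 log units; beyond the scatter) and a 33-fold lower number from compound 1 to compound 3 (1.51 log units; beyond the scatter) both beyond the scatter. The next member, compound 4 `O=C(CCCCCCCC(=O)c1ccc(N2CCCCC2)cc1)NO`, keeps the shared core of compound 3 and changes one group: piperidin-1-yl in place of 4-bromophenyl on an aromatic carbon.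

Within the data shown here, two measured steps bear on this change. Adding the 4-bromophenyl to the bare ring gave a 33-fold lower number from compound 1 to compound 3 (1.51 log units; beyond the scatter); exchanging methoxy for 4-bromophenyl gave a 7.5-fold lower number from compound 2 to compound 3 (0.88 log units; beyond the scatter). Both say that the 4-bromophenyl carries much of the gain seen at compound 3, so removing it is expected to cost. Among the measured compounds shown here, no measured pair shows the piperidin-1-yl itself; the nearest guide is compound 2, where a single group on the same ring position gave a 4.3-fold lower number from compound 1 to compound 2 (0.64 log units; beyond the scatter) over compound 1. Compound 4 is therefore expected to land between compound 2 and compound 3, with a step of a 4.0-fold higher number from compound 3 to compound 4 (0.60 log units; beyond the scatter) in this assay. The estimate for compound 4 is 8 nM, range 3 nM to 25 nM.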

Compound 4, half-maximal inhibitory concentration: 9.5 nM
Estimate against measurement, compound 4: 1.2-fold (0.07 log units) below; the range from low to high includes it.
By their numbers in this assay, from the lowest: compound 3; then compounds 4 and 2 (each within the scatter of the next); then compound 1.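

In this assay, piperidin-1-yl still improves on the bare ring, with a 6.8-fold lower number from compound 1 to compound 4 (0.84 log units; beyond the scatter) at this position, so the gain does not depend on an aromatic ring in the entering group. Among these compounds, the aromatic 4-bromophenyl is not matched by this non-aromatic ring, as a 4.8-fold higher number from compound 3 to compound 4 (0.68 log units; beyond the scatter) shows, and the highest activity so far stays with compound 3. Against methoxy the change gives a 1.6-fold lower number from compound 2 to compound 4 (0.20 log units; within the scatter) and so does not separate the two groups, which means a ring with one hetero atom offers no measurable advantage over that much smaller substituent here.

Open, on these data alone, are whether plain phenyl, without the bromine, or morpholin-4-yl would follow compound 3 or compound 4, and whether a shorter chain would preserve these differences. No measurement at hand accounts for any of these steps.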